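The source may report more compounds than this note shows. Statements on the series, on what has been measured and on what is new or still open speak of the compounds shown alone.

Measured in a functional assay on MIA PaCa-2 cells (Homo sapiens) for inhibition, read by MTT assay, with a stated time of 7 days; on this read-out lower numbers stand for stronger inhibition and higher numbers for weaker inhibition:

- compound 1 `CCOC(=O)[C@@H]1CCCN(S(=N)(=O)c2ccc(S(=O)(=O)N(CC)CC)cc2)C1`: 12100 nM
- compound 2 `CCN(CC)S(=O)(=O)c1ccc(S(=O)(=O)N2CCC[C@@H](C(=O)N(C)C(C)C)C2)cc1`: 6200 nM

Compound 2, at 6200 nM, lies within the usual scatter of compound 1, at 12100 nM, so these two numbers cannot be ranked. Compound 3 `CCN(CC)S(=O)(=O)c1ccc(S(=O)(=O)N2CCC[C@@H](C(=O)NC3COC3)C2)cc1` differs from compound 2 at the amide: (oxetan-3-yl)amino in place of isopropyl(methyl)amino on a carbonyl carbon. Here (oxetan-3-yl)amino takes the place of isopropyl(methyl)amino on a carbonyl carbon. Among the compounds with values here, no two measured compounds differ in one place alone, so this expectation is uncertain. The expected change is a 1.5-fold higher number from compound 2 to compound 3 (0.16 log units; within the scatter), a modest move towards weaker inhibition in this assay that may stay within the scatter. For compound 3 the estimated value is 9000 nM, with an expected range from 3000 nM to 27000 nM.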

Compound 3, half-maximal inhibitory concentration: 2300 nM
Estimate against measurement, compound 3: 3.9-fold (0.59 log units) above; measured number outside the range, below it.
By their numbers in this assay, from the lowest: compound 3; then compounds 2 and 1 (each within the scatter of the next).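

In this assay the amide on the carbonyl carbon proves to be a place where a change can be read: (oxetan-3-yl)amino in place of isopropyl(methyl)amino gives a 2.7-fold lower number from compound 2 to compound 3 (0.43 log units; beyond the scatter), a step beyond the scatter towards stronger inhibition. Both groups have the same number of heavy atoms, but the entering one brings a four-membered ring with an oxygen, a hydrogen-bond donor and a hydrogen-bond acceptor. Nothing shown here accounts for the gain. Going by these compounds, it remains open which of these features matters, and whether cyclobutylamino, with carbon in place of the ring oxygen, or an open-chain 2-methoxyethylamino group would behave the same way.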